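Removing the 4-methoxybenzyl group from compound 2

The compounds below may be only part of what the source reports. "The series", "measured", "known", "first", "only" and "open" are said of these compounds alone.

In a functional assay on DU-145 cells (Homo sapiens) for antiproliferative activity, read by WST assay, with a stated time of 3 days (a higher number here means a weaker inhibitor, a lower number a stronger inhibitor), compound 2 (`COc1ccc(COC[C@H]2C/C(C)=C/COCC/C=C/C(=O)C/C(C)=C\C=C\C(=O)O2)cc1`) holds the lower of the two measured numbers, with 3160 nM as its reading. Compound 1 (`C/C1=C/C=C/C(=O)O[C@H](CO)C/C(C)=C/COCC/C=C/C(=O)C1`) reads 17800 nM in this assay and so is the weaker inhibitor, with the gap beyond the scatter. Compound 3 (`C/C1=C/C=C/C(=O)O[C@@H](CO)C/C(C)=C/COCC/C=C/C(=O)C1`) has not yet been measured. Its structure differs from compound 2 by hydrogen in place of 4-methoxybenzyl on an oxygen on a saturated carbon, which turns ((4-methoxybenzyl)oxy)methyl into hydroxymethyl. Compound 1 also carries hydroxymethyl and reads 17800 nM in this assay, so a step towards a higher number, beyond the scatter, is expected. The estimated step of a 3.8-fold higher number from compound 2 to compound 3 (0.58 log units; beyond the scatter) is expected to mean weaker inhibition. For compound 3 the expected value is 12000 nM (estimated range 4000 nM to 35000 nM).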

Compound 3, half-maximal inhibitory concentration: > 30000 nM
Compound 3 gave a limit, no number; the forecaster's own chance of this, stated with the estimate: 15%; at least 2.5-fold (0.39 log units) between middle value and limit.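

In this assay compound 3 gives > 30000 nM, which is a limit of the assay and not a number. Even so, the pair with one difference shows that replacing 4-methoxybenzyl with hydrogen on this oxygen weakens inhibition, with an at least 9.4-fold higher number from compound 2 to compound 3 (0.97 log units; beyond the scatter), a change the earlier compounds could not isolate. The drawn stereocentre remains unresolved, since the floor of an at least 1.6-fold higher number from compound 1 to compound 3 (0.22 log units; that floor lies within the scatter) does not establish a difference between these two compounds: the fact that compounds 1 and 3 differ only in the configuration as drawn

As far as these compounds go, the true size of both steps remains open, as does whether the configuration at this stereocentre matters when the 4-methoxybenzyl group is present. From the compounds shown here alone, it is also open whether the methoxy group or the benzyl part accounts for the stronger reading of compound 2, a question that a plain benzyl ether or a methyl ether on this oxygen would address.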